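Same side group added to a stronger core

The compounds below may be only part of what the source reports. "The series", "measured", "known", "first", "only" and "open" are said of these compounds alone.

Compound 1 `O=C(NCc1ccccc1)c1ccc(-c2ccccc2)nc1` is the starting point; in an assay on isolated protein for inhibition of Hematopoietic prostaglandin D synthase (Homo sapiens), read by ELISA (a higher number here means a weaker inhibitor, a lower number a stronger inhibitor), compound 1 gives 1230 nM. For the measured compounds named here, compound 2 `O=C(NCc1ccccc1)c1cnc(-c2ccccc2)nc1` carries a different core, and the difference between the two cores is not broken down here; in this assay compound 2 gives 23.9 nM, the lowest of the three numbers so far. Compound 3 `CC(C)(O)c1nc(-c2cccc(CNC(=O)c3ccc(-c4ccccc4)nc3)c2)no1` arises from compound 1 by 5-(1-hydroxy-1-methylethyl)-1,2,4-oxadiazol-3-yl in place of hydrogen on an aromatic carbon; in this assay compound 3 gives 808 nM, and that step gave a 1.5-fold lower number from compound 1 to compound 3 (0.18 log units; within the scatter). Compound 4 `CC(C)(O)c1nc(-c2cccc(CNC(=O)c3cnc(-c4ccccc4)nc3)c2)no1` has not yet been measured. It arises from compound 2 by the same change, (5-(1-hydroxy-1-methylethyl)-1,2,4-oxadiazol-3-yl in place of hydrogen on an aromatic carbon). The step expected from compound 2 to compound 4 is a 1.4-fold lower number from compound 2 to compound 4 (0.15 log units; within the scatter), set beside the earlier step, because the same change on compound 1 gave a 1.5-fold lower number from compound 1 to compound 3 (0.18 log units; within the scatter). On that basis compound 4 is estimated at 17 nM, expected to fall between 6 nM and 50 nM.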

Compound 4, half-maximal inhibitory concentration: 9.86 nM
For compound 4 the middle estimate is 1.7-fold (0.24 log units) above the measured one; the range from low to high includes it.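

Adding the 5-(1-hydroxy-1-methylethyl)-1,2,4-oxadiazol-3-yl group to the stronger of the two cores gave a 2.4-fold lower number from compound 2 to compound 4 (0.38 log units; beyond the scatter) in this assay. Set beside the earlier step, the change carried over from one core to the other with no difference that can be told from scatter: the same change on two cores in this assay, a 1.5-fold lower number (0.18 log units; within the scatter) from compound 1 to compound 3 and a 2.4-fold lower number (0.38 log units; beyond the scatter) from compound 2 to compound 4, 1.6-fold (0.20 log units) apart, within the scatter of two such steps. This holds for these two cores only, and it does not show how the same change would behave on any other core or why its effect has this size.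

Going by these compounds, it remains open whether a simpler group on the same aromatic carbon, such as an amine or a carboxylic acid, would give a similar step. On these data alone, it is also open whether the oxadiazole ring would give that step without its 1-hydroxy-1-methylethyl group.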